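This account rests on a few compounds, and the source may have more. Where it says the series, first, only, none or still open, it means among the compounds named here.

Of the compounds shown here, three sharing one core have been tested in an ADME assay on BJ cells (Homo sapiens) for cytotoxicity, read by CellTiter-Glo and resazurin assay, with a stated time of 72 h; on this read-out lower numbers stand for an effect already at smaller amounts and higher numbers for an effect only at larger amounts of compound. Compound 1, `CC(=O)Nc1cccc(-c2ccc(C(=O)N(Cc3cccc(OCCCCCC(=O)O)c3)C(C)C)cc2)c1`, gives a result that is only a limit of the measurement, > 26000 nM. Compound 2, `CC(C)N(Cc1cccc(OCCCCCC(=O)O)c1)C(=O)c1ccc(-c2ccoc2)cc1`, likewise gives only a limit, > 26000 nM. Compound 3, `COc1cccc(-c2ccc(C(=O)N(Cc3cccc(OCCCCCC(=O)O)c3)C(C)C)cc2)c1`, also gives only a limit, > 20900 nM. Compound 3 therefore stands where the other two stand, at a limit, so no order among the three can be read. The steps a step that the two limits leave unreadable from compound 1 to compound 2, a step that the two limits leave unreadable from compound 1 to compound 3 and a step that the two limits leave unreadable from compound 2 to compound 3 are all unreadable because both ends of each sit at the limit of > 20900 nM in this assay, at which 1 of the 3 values shown sits, or (the limit of > 26000 nM in this assay, at which 2 of the 3 values shown sit). Compound 4, `CC(C)N(Cc1cccc(OCCCCCC(=O)O)c1)C(=O)c1ccc(-c2cccc(C(F)(F)F)c2)cc1`, differs from compound 3 by trifluoromethyl in place of methoxy on an aromatic carbon. The measured steps that bear on this change are those into compound 3, and none of them has a readable size, so they give no sign of a direction. The expectation in this assay is therefore no step beyond the scatter, and most likely another limit. The step that the limit leaves unreadable from compound 3 to compound 4 is the expected size. Compound 4 is expected to give 30000 nM, between 12000 nM and 70000 nM.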

Compound 4, half-maximal effective concentration: > 26000 nM
Compound 4: no number, only a limit; the forecaster's own chance of this, stated with the estimate: 85%; the middle value does not contradict the limit.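

In this assay compound 4 gives > 26000 nM, which is only a limit. Going by these compounds alone, compound 1, compound 2 and compound 3 also give only limits, so no step from any of them to compound 4 can be read. The compounds shown leave open whether changing this group on the shared core alters the effect on these cells at all.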